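Working notes: sulfonyl change on the strongest amide

The source may hold more compounds than are shown below. What is called first, only, known or untested is meant among the compounds shown, and "the series" means these compounds.

Measured in an assay for inhibition of Nicotinamide phosphoribosyltransferase (Homo sapiens), read by mass spectrometry, with stated times of 15 min and 30 min; a lower number here means a stronger inhibitor, a higher number a weaker inhibitor:
- compound 1, `O=C(NCc1ccc(S(=O)(=O)N2CCCCC2)cc1)c1cc2cnccc2o1`: 140 nM
- compound 2, `O=C(NCc1ccc(S(=O)(=O)N2CCCCC2)cc1)c1cnc2nccn2c1`: 3 nM
- compound 3, `O=C(NCc1ccc(S(=O)(=O)N2CCCCC2)cc1)c1cc2ccncc2o1`: 40 nM

Compound 2 gives the lowest of the three numbers. The gap to its nearest neighbour is a 13-fold higher number from compound 2 to compound 3 (1.12 log units; beyond the scatter), and to the furthest a 47-fold lower number from compound 1 to compound 2 (1.67 log units; beyond the scatter); both lie beyond the scatter. The remaining pair shows a 3.5-fold lower number from compound 1 to compound 3 (0.54 log units; beyond the scatter). All three measured steps change only the group on the carbonyl carbon; the sulfonyl end is the same in every measured compound.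

Compound 4 is `O=C(NCc1ccc(S(=O)(=O)c2ccccc2)cc1)c1cnc2nccn2c1`. It differs from compound 2 by phenyl in place of piperidin-1-yl on a sulfonyl sulfur. Among the measured compounds shown here, no measured step touches this part of the molecule, so there is no step on record that bears on the change, and no direction can be read from the series. In the absence of such a step, compound 4 is expected to stay near compound 2, with a step of a 1.7-fold higher number from compound 2 to compound 4 (0.22 log units; within the scatter), most likely within the scatter. The estimate for compound 4 is 5 nM, in the range 1.5 nM to 20 nM.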

Compound 4, half-maximal inhibitory concentration: 2 nM
Beside the measured number, compound 4's estimate is 2.5-fold (0.40 log units) above it; the range from low to high includes it.
By their numbers in this assay, from the lowest: compounds 4 and 2 (each within the scatter of the next); then compound 3; then compound 1.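

Among the compounds shown here, the sulfonyl end can now be read for the first time: with the group on the carbonyl carbon held as in compound 2, phenyl in place of piperidin-1-yl on a sulfonyl sulfur gives a 1.5-fold lower number from compound 2 to compound 4 (0.18 log units; within the scatter) in this assay. This single step shows that a six-membered non-aromatic ring with one nitrogen and a six-membered aromatic ring of carbon only are not told apart here, so the large steps in the series remain those on the carbonyl carbon. Nothing at hand explains why these two groups read alike.

Open, on these data alone, is whether a group of another kind on the sulfonyl sulfur, such as a carboxylic acid, an amine or a longer alkyl chain, would also read alike. Also open, as far as these compounds go, is whether the same exchange holds with the carbonyl groups of compound 1 and compound 3.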